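This account rests on a few compounds, and the source may have more. Where it says the series, first, only, none or still open, it means among the compounds named here.

Compound 1 (`COC(=O)c1cc(-c2cccc(NC(=O)c3ccc(/C=C/C(=O)c4ccc(OC)cc4OC)cc3)c2)on1`) is one of three close relatives tested in an ADME assay on Vero cells (Chlorocebus sabaeus) for cytotoxicity, read by MTT assay, with a stated time of 72 h; on this read-out lower numbers stand for higher toxicity in this test and higher numbers for lower toxicity in this test. In this assay compound 1 gives > 50 ug/mL, which is a limit of the assay rather than a number. Compound 2 (`COC(=O)c1cc(-c2cccc(NC(=O)c3ccc(/C=C/C(=O)c4ccc(Br)cc4)cc3)c2)on1`) gives in this assay > 20 ug/mL, again only a limit. Compound 3 (`COC(=O)c1cc(-c2cccc(NC(=O)c3ccc(/C=C/C(=O)c4ccc(F)cc4F)cc3)c2)on1`) gives in this assay > 40 ug/mL, also a limit. All three values therefore sit at limits (the limit of > 20 ug/mL in this assay, at which 1 of the 3 values shown sits, (the limit of > 40 ug/mL in this assay, at which 1 of the 3 values shown sits), (the limit of > 50 ug/mL in this assay, at which 1 of the 3 values shown sits)), and none of the steps between them can be sized: a step that the two limits leave unreadable from compound 1 to compound 2, a step that the two limits leave unreadable from compound 1 to compound 3 and a step that the two limits leave unreadable from compound 2 to compound 3 stay unreadable.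

Compound 4 (`COC(=O)c1cc(-c2cccc(NC(=O)c3ccc(/C=C/C(=O)c4ccc(OC)c([N+](=O)[O-])c4)cc3)c2)on1`) has not yet been measured in this assay. It differs from compound 1 at the same place where compounds 2 and 3 differ from it: 4-methoxy-3-nitrophenyl in place of 2,4-dimethoxyphenyl on a carbonyl carbon. The two steps that bear on this change are the unreadable ones from compound 1 to compound 2 and from compound 1 to compound 3, and they give no direction. Compound 4 is therefore expected to give 60 ug/mL in this assay, estimated within 20 ug/mL to 150 ug/mL. The expected step is a step that the limit leaves unreadable from compound 1 to compound 4, which is nothing beyond the scatter.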

Compound 4, half-maximal cytotoxic concentration: > 40 ug/mL
Compound 4 gave a limit, no number (the forecaster's own chance of this, stated with the estimate: 75%); the middle value is on the limit's open side.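

In this assay compound 4 gives > 40 ug/mL, which is a limit and not a number. Among the compounds shown here, compound 1, compound 2 and compound 3 also gave only limits, so no step to compound 4 can be read. Going by these compounds, whether swapping the group on the carbonyl carbon changes toxicity in this test stays open.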